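An Unmeasured Stereoisomer of Compound 2

This account rests on a few compounds, and the source may have more. Where it says the series, first, only, none or still open, it means among the compounds named here.

Of the compounds shown here, two have been tested so far, compound 1 (`CO[C@@H]1[C@H]2[C@@H]([C@@H](OC(=O)[C@@]3(C)C[C@H]3C)[C@@H](C)C(=O)[C@@]34C[C@H](C)[C@H](OC(C)=O)[C@]3(/C=C(\C)[C@H]1OC(C)=O)O4)C2(C)C`) and compound 2 (`C/C=C(/C)C(=O)O[C@@H]1/C(C)=C/[C@@]23O[C@@]2(C[C@H](C)[C@@H]3O)C(=O)[C@H](C)[C@H](O)[C@@H]2[C@H]([C@H]1OC)C2(C)C`). In a functional assay on A549 cells (Homo sapiens) for cytotoxicity (on this read-out higher numbers stand for weaker inhibition and lower numbers for stronger inhibition), compound 1 reads < 10000 nM as a limit of the assay and not a number. In this assay compound 2 reads < 10000 nM as a limit as well, so its position is known only as a limit and not as an exact number. Both results sit at the same limit (the limit of < 10000 nM in this assay, at which 2 of the 2 values shown sit).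

Compound 3 (`C/C=C(/C)C(=O)O[C@@H]1/C(C)=C/[C@@]23O[C@@]2(C[C@@H](C)[C@H]3O)C(=O)[C@H](C)[C@H](O)[C@@H]2[C@H]([C@H]1OC)C2(C)C`) is the next to be tested. The difference from compound 2 is one of configuration alone (the two compounds have the same atoms and bonds and differ only in configuration as drawn: 2 of 12 stereo elements differ; a stereocentre at a saturated ring carbon is drawn S in compound 2 and R in compound 3; a stereocentre at a saturated ring carbon is drawn S in compound 2 and R in compound 3). For the measured compounds named here, no measured pair shows what such a change in configuration does in this assay, and neither limit gives a firm starting number. The expectation is therefore for no change beyond the usual scatter, with no direction favoured. The estimated change is a step that the limit leaves unreadable from compound 2 to compound 3 and should be read as an expected value only. Compound 3 is expected to read about 6000 nM in this assay with an estimated range of 2000 nM to 10000 nM as its likely span.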

Compound 3, half-maximal inhibitory concentration: < 10000 nM
Compound 3 ended at the assay's limit (the forecaster's own chance of this, stated with the estimate: 60%); the middle value lies beyond the limit too.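

No step from compound 2 to compound 3 can be read, because both results are limits and not numbers: the limit of < 10000 nM in this assay, at which 3 of the 3 values shown sit.

The compounds shown leave open whether the difference in configuration between compound 2 and compound 3 changes the result at all in this assay, and what exact value any of the three compounds would have.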